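The source may hold more compounds than are shown below. What is called first, only, known or untested is meant among the compounds shown, and "the series" means these compounds.

Compound 3 `C/C(=N\NC(N)=O)c1ccc2c(c1)nc(-c1ccccc1)n2C1CCCCC1` stands only at a limit in an ADME assay on MDBK cells (Bos taurus) for cytotoxicity, read by MTT assay, with a stated time of 96 h (a lower number here means that less compound is tolerated, a higher number that more compound is tolerated), with > 100000 nM as its reading and no number behind it. Compound 2 `CC(=O)c1ccc2c(c1)nc(-c1ccccc1)n2C1CCCCC1` also gives only a limit, > 100000 nM in this case. Together they make up (the limit of > 100000 nM in this assay, at which 2 of the 3 values shown sit), so the ceiling of the read-out is all that is known for this pair.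

The next step leads to compound 4 `COc1ccc(-c2nc3cc(/C(C)=N/NC(N)=O)ccc3n2C2CCCCC2)cc1` through (methoxy in place of hydrogen on an aromatic carbon), which reads as phenyl to 4-methoxyphenyl. Going by the values given here, the one measured step, a step that the two limits leave unreadable from compound 2 to compound 3, concerns a different place and gives no size to carry over. The nearest guide is compound 1 `COc1ccc(-c2nc3cc(/C(C)=N/NC(N)=O)ccc3[nH]2)cc1`, which also carries 4-methoxyphenyl and gives 25000 nM in this assay, though it differs from compound 4 elsewhere. A move towards lower numbers, meaning less compound tolerated, is therefore expected, but compound 4 may well stay at the limit.

The expected change is an at least 1.5-fold lower number from compound 3 to compound 4 (0.18 log units; that floor lies within the scatter) as an estimate. For compound 4 the estimated value is 65000 nM, with an expected range from 25000 nM to 100000 nM.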

Compound 4, half-maximal cytotoxic concentration: 54000 nM
The estimate for compound 4 lay 1.2-fold (0.08 log units) above the measured number; the measured number falls inside the stated range.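

In this assay, methoxy in place of hydrogen on an aromatic carbon gives an at least 1.8-fold lower number from compound 3 to compound 4 (0.26 log units; that floor lies within the scatter), so phenyl to 4-methoxyphenyl brings a compound carrying cyclohexyl on the aromatic nitrogen to a numeric reading, though the size of the change is known only as a floor. Compound 3 gives > 100000 nM, which is a limit, and its true distance from compound 4 stays unknown: the limit of > 100000 nM in this assay, at which 2 of the 4 values shown sit.

Going by these compounds alone, with 4-methoxyphenyl present in both compounds, cyclohexyl in place of hydrogen on an aromatic nitrogen gives a 2.2-fold higher number from compound 1 to compound 4 (0.33 log units; beyond the scatter), the first step with a readable size, in the direction of more compound tolerated.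

The compounds shown leave open how an amine or a chlorine would read in place of methoxy on the same ring. They also leave open whether a shorter group such as ethyl on the aromatic nitrogen would give a step of similar size.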